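Swapping Methoxy for Trifluoromethyl on the Pendant Phenyl

This account rests on a few compounds, and the source may have more. Where it says the series, first, only, none or still open, it means among the compounds named here.

Compound 1, `COc1ccc(-c2c(C3=NN(C(=O)CCC(=O)O)C(c4ccc(Cl)cc4)C3)c(=O)[nH]c3ccccc23)cc1`, in an assay on cells (Oocyte) for negative allosteric modulation of glutamate receptor ionotropic, NMDA 2D (Rattus norvegicus), read by two-electrode voltage clamp; on this read-out higher numbers stand for weaker inhibition and lower numbers for stronger inhibition: 2300 nM
Compound 2, `COc1cccc(-c2c(C3=NN(C(=O)CCC(=O)O)C(c4ccc(Cl)cc4)C3)c(=O)[nH]c3ccccc23)c1`, in this assay: 4500 nM

Of these two numbers, compound 2 sits at the upper one, but a 2.0-fold higher number from compound 1 to compound 2 (0.29 log units; within the scatter), so the two compounds cannot be told apart. Compound 3, `O=C(O)CCC(=O)N1N=C(c2c(-c3cccc(C(F)(F)F)c3)c3ccccc3[nH]c2=O)CC1c1ccc(Cl)cc1`, differs from compound 2 by trifluoromethyl in place of methoxy on an aromatic carbon. Within the data shown here, no measured pair shows this exchange; the only known step concerns where the methoxy sits and stays within the scatter. With nothing pointing in either direction, compound 3 is expected to give 4000 nM (range 1300 nM to 12000 nM), and the expected step of a 1.1-fold lower number from compound 2 to compound 3 (0.05 log units; within the scatter) is none beyond the scatter.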

Compound 3, half-maximal inhibitory concentration: 2600 nM
Beside the measured number, compound 3's estimate is 1.5-fold (0.19 log units) above it, and the stated range covers the measured number.
By their numbers in this assay, from the lowest: compounds 1, 3 and 2 (each within the scatter of the next).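

Trifluoromethyl can stand in for methoxy on this aromatic carbon with no readable effect in this assay, giving a 1.7-fold lower number from compound 2 to compound 3 (0.24 log units; within the scatter). Compound 3 is equally hard to separate from the other methoxy compound, with a 1.1-fold higher number from compound 1 to compound 3 (0.05 log units; within the scatter), so on these compounds the exchange of a hydrogen-bond acceptor group for one without an acceptor does not register beyond the scatter. No measurement is at hand that would explain this result. From the compounds shown here alone, whether an amine or a carboxylic acid on this phenyl would shift the number beyond the scatter remains open.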